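Terminal aryl swaps on a bombesin receptor subtype-3 series

A few compounds are considered here, and "the series" means these few. Any claim that something is new, unique, unknown or untested is made for them only; others in the source may bear on it.

compound 1 `CCC(C)(C)Cc1c[nH]c(CCc2ccc(-c3cccc(N)n3)cc2)n1`: 97 nM
compound 2 `CCC(C)(C)Cc1c[nH]c(CCc2ccc(-c3csnn3)cc2)n1`: 104 nM

In a functional assay on HEK293 cells for agonist activity at Bombesin receptor subtype-3 (Homo sapiens), read by luminescence and calcium flux, with a stated time of 10 min (on this read-out higher numbers stand for an effect only at larger amounts of compound and lower numbers for an effect already at smaller amounts), compound 2 and compound 1 sit within the scatter of each other; a 1.1-fold higher number from compound 1 to compound 2 (0.03 log units; within the scatter). Compound 3 `CCC(C)(C)Cc1c[nH]c(CCc2ccc(-c3cccnc3)cc2)n1` differs from compound 2 by pyridin-3-yl in place of 1,2,3-thiadiazol-4-yl on an aromatic carbon. Among the measured compounds shown here, the one step that bears on this change is a 1.1-fold higher number from compound 1 to compound 2 (0.03 log units; within the scatter), an exchange of one aromatic group for another at the same place, and it stayed within the scatter. For compound 3 a step of a 1.0-fold higher number from compound 2 to compound 3 (0.00 log units; within the scatter) is therefore expected, none beyond the scatter. Compound 3 is estimated at 105 nM in this assay, within 45 nM to 250 nM.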

Compound 3, half-maximal effective concentration: 98 nM
The estimate for compound 3 lay 1.1-fold (0.03 log units) above the measured number; measured number inside the range.
By their numbers in this assay, from the lowest: compounds 1, 3 and 2 (each within the scatter of the next).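

In this assay, pyridin-3-yl joins the two earlier aromatic groups at this place on the shared core, with a 1.1-fold lower number from compound 2 to compound 3 (0.03 log units; within the scatter) and a 1.0-fold higher number from compound 1 to compound 3 (0.00 log units; within the scatter) both inside the scatter. Exchanging a five-membered aromatic ring with 3 hetero atoms for a six-membered one with 1 hetero atom therefore leaves the number unmoved within the scatter. Nothing on hand explains this flat picture.

Open, as far as these compounds go, is whether an unsubstituted phenyl ring would also stay within the scatter. Also open, from the compounds shown here alone, is whether a carboxylic acid or a non-aromatic amine at this place would shift the number.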